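The source may report more compounds than this note shows. Statements on the series, on what has been measured and on what is new or still open speak of the compounds shown alone.

Values in an assay on isolated protein for inhibition of Fatty-acid amide hydrolase 1 (Homo sapiens), with a stated time of 60 min; on this read-out higher numbers stand for weaker inhibition and lower numbers for stronger inhibition:
- compound 1 `Cc1nc2cc(NC(=O)N3CCN(Cc4cccc(Oc5ccc(Cl)cc5)c4)CC3)ccc2o1` gives 7.7 nM
- compound 2 `O=C(Nc1noc2ccccc12)N1CCN(Cc2cccc(Oc3ccc(Cl)cc3)c2)CC1` gives 10 nM
- compound 3 `O=C(Nc1ccn2ccnc2c1)N1CCN(Cc2cccc(Oc3ccc(Cl)cc3)c2)CC1` gives 33 nM

Compound 1 has the lowest of the three numbers. Its nearest neighbour is compound 2, with a 1.3-fold higher number from compound 1 to compound 2 (0.11 log units; within the scatter), so the two cannot be ordered. For the measured compounds named here, the only step beyond the scatter leads to compound 3, with a 4.3-fold higher number from compound 1 to compound 3 (0.63 log units; beyond the scatter); likewise a 3.3-fold higher number from compound 2 to compound 3 (0.52 log units; beyond the scatter).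

Compound 4 `O=C(Nc1ccc2nccn2c1)N1CCN(Cc2cccc(Oc3ccc(Cl)cc3)c2)CC1` has not yet been measured. Relative to compound 1 the change is a group of 9 heavy atoms (7 carbon, 2 nitrogen; one five-membered aromatic ring with 2 hetero atoms, one six-membered aromatic ring with 1 hetero atom) in place of a group of 10 heavy atoms (8 carbon, 1 nitrogen, 1 oxygen; one five-membered aromatic ring with 2 hetero atoms, one six-membered aromatic ring of carbon only), on an amide-type nitrogen. The entering group has the same description as the one that enters in the step to compound 3: a group of 9 heavy atoms (7 carbon, 2 nitrogen; one five-membered aromatic ring with 2 hetero atoms, one six-membered aromatic ring with 1 hetero atom) on an amide-type nitrogen; only the point of attachment differs. Going by the values given here, the steps that bear on this are therefore a 4.3-fold higher number from compound 1 to compound 3 (0.63 log units; beyond the scatter) and a 3.3-fold higher number from compound 2 to compound 3 (0.52 log units; beyond the scatter), both modest and in the direction of a higher number. Among the compounds with values here, no measured pair tells how much the attachment point itself matters.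

The expectation for compound 4 is a modest rise in this assay over compound 1, of the order of a 3.2-fold higher number from compound 1 to compound 4 (0.51 log units; beyond the scatter), because of a 4.3-fold higher number from compound 1 to compound 3 (0.63 log units; beyond the scatter). Compound 4 is estimated at 25 nM, with a range of 9 nM to 70 nM.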

Compound 4, half-maximal inhibitory concentration: 100 nM
Estimate against measurement, compound 4: 4.0-fold (0.60 log units) below; measured number outside the range, above it.
By their numbers in this assay, from the lowest: compounds 1 and 2 (each within the scatter of the next); then compound 3; then compound 4.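

In this assay, the group on the amide-type nitrogen proves more sensitive than compound 3 alone indicated: there is a 13-fold higher number from compound 1 to compound 4 (1.11 log units; beyond the scatter), a large step, and a 10-fold higher number from compound 2 to compound 4 (1.00 log units; beyond the scatter), which leaves compound 4 the weakest of the four. Compounds 3 and 4 give the first measure of the attachment point: their entering groups share the same atom count and ring description, yet there is a 3.0-fold higher number from compound 3 to compound 4 (0.48 log units; beyond the scatter), so on this nitrogen the composition of the group does not fix the number and the way it is attached also counts. Nothing on hand bears on the reason for these differences.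

Only two attachment points of this entering group appear, and every compound shown keeps the rest of the molecule unchanged, so it remains open whether the same order would hold on a different remainder. Also open, as far as these compounds go, is whether an amine or a carboxylic acid on the entering group, or an ethyl in place of the methyl of 2-methyl-1,3-benzoxazol-5-yl, would shift the number on this read-out.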